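A few compounds are considered here, and "the series" means these few. Any claim that something is new, unique, unknown or untested is made for them only; others in the source may bear on it.

Compound 1 `CCOC(=O)c1ccc(NC(=O)N2CC2C#N)cc1`: in a functional assay on A549 cells (Homo sapiens) for inhibition (a lower number here means a stronger inhibitor, a higher number a weaker inhibitor), compound 1 gives 2900 nM.
Compound 2 `N#CC1CN1C(=O)Nc1ccc(S(N)(=O)=O)cc1`: in this assay compound 2 gives only a limit of the assay, > 38000 nM.
Compound 3 `N#CC1CN1C(=O)Nc1ccc([N+](=O)[O-])cc1`: in this assay compound 3 gives 3900 nM.

Compound 3 holds the higher of the two numbers in the series, but its nearest neighbour is close: a 1.3-fold higher number from compound 1 to compound 3 (0.13 log units; within the scatter), within the scatter. The third value is a limit, so it cannot be ordered against the other two beyond the statement (the limit of > 38000 nM in this assay, at which 1 of the 3 values shown sits).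

Compound 4 `N#CC1CN1C(=O)Nc1ccc(C(F)(F)F)cc1` is the next candidate. Its difference from compound 3 is trifluoromethyl in place of nitro on an aromatic carbon. Among the compounds with values here, no measured step contains trifluoromethyl, so the three steps on this aromatic carbon serve only as a frame. Swapping ethoxycarbonyl for nitro moved little, a 1.3-fold higher number from compound 1 to compound 3 (0.13 log units; within the scatter). Sulfamoyl stood apart: an at least 13-fold higher number from compound 1 to compound 2 (1.11 log units; beyond the scatter) and, going back, an at least 9.7-fold lower number from compound 2 to compound 3 (0.98 log units; beyond the scatter). Two of three groups tried at this position therefore sit in the same range, one falls out to the limit.

Within the data shown here, with no direct precedent for trifluoromethyl, the expectation for compound 4 in this assay is a step no larger than the scatter, a 1.1-fold lower number from compound 3 to compound 4 (0.05 log units; within the scatter), in either direction. Compound 4 is estimated at 3500 nM, with a range from 1000 nM to 14000 nM.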

Compound 4, half-maximal inhibitory concentration: 4300 nM
The estimate for compound 4 lay 1.2-fold (0.09 log units) below the measured number; the range from low to high includes it.
By their numbers in this assay, from the lowest: compounds 1, 3 and 4 (each within the scatter of the next). At a limit, above all of these: compound 2.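

Trifluoromethyl, which has no hydrogen-bond donors or acceptors, cannot be separated from nitro in this assay: a 1.1-fold higher number from compound 3 to compound 4 (0.04 log units; within the scatter). It also cannot be separated from ethoxycarbonyl, a 1.5-fold higher number from compound 1 to compound 4 (0.17 log units; within the scatter), so compounds 1, 3 and 4 now form a group of three whose numbers lie within the scatter, and the earlier agreement between ethoxycarbonyl and nitro extends to a group with a different atom make-up. Sulfamoyl remains the one exception among the four groups at this aromatic carbon, with an at least 8.8-fold lower number from compound 2 to compound 4 (0.94 log units; beyond the scatter), and the value of compound 2 is a limit of the assay: the limit of > 38000 nM in this assay, at which 1 of the 4 values shown sits.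

The compounds shown do not establish what sets sulfamoyl apart, since one group against three supports no rule about this position and no measured property is available to explain the gap. An amine, a carboxylic acid or a longer chain on this aromatic carbon would show whether the shared range of compounds 1, 3 and 4 extends further or whether more groups fall out with sulfamoyl.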